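This account rests on a few compounds, and the source may have more. Where it says the series, first, only, none or still open, it means among the compounds named here.

Series notes. Compound 1 `COc1ccc(/C=C/C(=O)c2c(O)cc(O)cc2OC)cc1` and compound 2 `COc1ccc(/C=C/C(=O)c2c(O)cc(O)cc2OC)cc1OC` share one core; the difference between that core and the core of compound 3 `COc1cc(/C=C/C(=O)c2c(OC)cc(OC)cc2OC)cc(OC)c1` is not broken down here. In a functional assay on A549 cells (Homo sapiens) for inhibition, read by MTT assay, with a stated time of 72 h (a lower number here means a stronger inhibitor, a higher number a weaker inhibitor), compound 1 gives > 50000 nM, which is a limit of the assay. Compound 2 gives > 50000 nM in this assay, also a limit. The change methoxy in place of hydrogen on an aromatic carbon thus yields a step that the two limits leave unreadable from compound 1 to compound 2, a step left unreadable by the limit of > 50000 nM in this assay, at which 2 of the 3 values shown sit. Going by the values given here, compound 3 gives 10100 nM in this assay, the one number in the set. Compound 4 `COc1cc(OC)c(C(=O)/C=C/c2cc(OC)c(OC)c(OC)c2)c(OC)c1`, not yet measured, carries methoxy in place of hydrogen on an aromatic carbon; it is the same kind of change as from compound 1 to compound 2, but sits ortho to two methoxy groups and para to a large group, where the earlier one sat ortho to a methoxy group and meta to a large group. With the measured pair giving no readable size, the expectation for compound 4 rests on compound 3 at 10100 nM alone. For compound 4 a step of a 2.0-fold lower number from compound 3 to compound 4 (0.31 log units; beyond the scatter) is expected. Compound 4 is estimated at 5000 nM in this assay, with a range from 1500 nM to 20000 nM.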

Compound 4, half-maximal inhibitory concentration: 22300 nM
The estimate for compound 4 lay 4.5-fold (0.65 log units) below the measured number; the measured number lies above the stated range.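

In this assay, methoxy in place of hydrogen on an aromatic carbon, ortho to two methoxy groups and para to a large group, gives a 2.2-fold higher number from compound 3 to compound 4 (0.34 log units; beyond the scatter), a modest weakening on the core of compound 3. The same kind of change on the core of compound 1 cannot be read, so no size from that core can be compared with this step: the limit of > 50000 nM in this assay, at which 2 of the 4 values shown sit. The step therefore describes one change at one place on one core and does not show whether the change carries over between cores.

Open, as far as these compounds go, is how an amine or a carboxylic acid in place of that methoxy would read in this assay. Also open, from the compounds shown here alone, is whether the core of compound 1 can give a readable number at all.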